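The compounds below may be only part of what the source reports. "The series", "measured", "known", "first", "only" and "open" are said of these compounds alone.

Compound 3 `CCNC(=O)CC1CCc2cc(OC)c(OC)cc21` gives 20.4% in a functional assay on the whole organism (strain Wistar) for inhibition, with Rattus norvegicus as the target, read by paw edema, with stated times of 60 min and 6 h, at a dose of 100 mg/kg by the oral route; on this read-out lower numbers stand for less inhibition and higher numbers for more inhibition at the one dose given (going by the name of the read-out). It is set apart beyond the scatter only from compound 2; from compound 1 it is not. Compound 1 `COc1cc2c(cc1OC)C(CC(N)=O)CC2` gives 27.8% and compound 2 `COc1cc2c(cc1OC)C(CC(=O)N(C)C)CC2` gives 33.3%, the two being joined by a number 5.5 percentage points higher from compound 1 to compound 2 (within the scatter), while a number 7.4 percentage points lower from compound 1 to compound 3 (within the scatter) and a number 12.9 percentage points lower from compound 2 to compound 3 (beyond the scatter) lead to compound 3. Compound 4 `CCCNC(=O)CC1CCc2cc(OC)c(OC)cc21` differs from compound 3 by methyl in place of hydrogen on a saturated chain carbon, two bonds along the chain from an amide-type nitrogen. Going by the values given here, no measured step alters the chain on the amide nitrogen in quite this way; the nearest comparison is a number 7.4 percentage points lower from compound 1 to compound 3 (within the scatter), which stayed within the scatter, whereas a number 12.9 percentage points lower from compound 2 to compound 3 (beyond the scatter) was modest. The expected step is therefore small, a number 0.4 percentage points lower from compound 3 to compound 4 (within the scatter), with no clear direction. Compound 4 is thus estimated at 20%, between 8% and 32%.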

Compound 4, a percentage reported as inhibition, in the whole organism at one dose (the size of the read-out at that dose, not a potency): 22.2%
Estimate against measurement, compound 4: 2.2 percentage points below; the range from low to high includes it.
By their numbers in this assay, from the lowest: compounds 3, 4, 1 and 2 (each within the scatter of the next, the first and the last beyond it).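

In this assay, ethylamino and propylamino on the carbonyl carbon cannot be told apart (a number 1.8 percentage points higher from compound 3 to compound 4 (within the scatter)), so the added methyl, two bonds along the chain from the amide-type nitrogen, gives no clear change. Propyl in place of hydrogen on that nitrogen also stays within the scatter of the unsubstituted amide (a number 5.6 percentage points lower from compound 1 to compound 4 (within the scatter)). The secondary propyl amide remains separated from the dimethylamino amide (a number 11.1 percentage points lower from compound 2 to compound 4 (beyond the scatter)), as the ethyl amide was. The compounds shown leave open whether a butyl chain, a longer chain or a carboxylic acid on this chain would read differently. No evidence here explains these numbers.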